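Removal of the indole substituent in a tamoxifen-like acrylic acid series

The source may report more compounds than this note shows. Statements on the series, on what has been measured and on what is new or still open speak of the compounds shown alone.

Measured so far:
Compound 1 `CC/C(=C(/c1ccc(/C=C/C(=O)O)cc1)c1[nH]c2ccccc2c1C#N)c1ccc(F)cc1Cl` — 4.85 nM
Compound 2 `CC/C(=C(/c1ccc(/C=C/C(=O)O)cc1)c1[nH]c2ccccc2c1C)c1ccc(F)cc1Cl` — 4.78 nM

In a functional assay on MCF7 cells (Homo sapiens) for antiproliferative activity, read by luminescence and CellTiter-Glo, with a stated time of 5 days (a lower number here means a stronger inhibitor, a higher number a weaker inhibitor), compound 1 gives 4.85 nM and compound 2 gives 4.78 nM. For the measured compounds named here, the only measured step, a 1.0-fold lower number from compound 1 to compound 2 (0.01 log units; within the scatter), exchanges one group for another on the five-membered ring without leaving the scatter, so compound 2 stands level with compound 1 rather than apart from it. Compound 3 `CC/C(=C(/c1ccc(/C=C/C(=O)O)cc1)c1cc2ccccc2[nH]1)c1ccc(F)cc1Cl` goes one step further: hydrogen in place of methyl on an aromatic carbon. Going by the values given here, no measured step removes the group entirely, so the cyano-to-methyl step is only a loose guide. The expectation is a small loss, a 1.9-fold higher number from compound 2 to compound 3 (0.27 log units; within the scatter), with compound 3 estimated at 9 nM (range 3 nM to 30 nM).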

Compound 3, half-maximal inhibitory concentration: 21 nM
Beside the measured number, compound 3's estimate is 2.3-fold (0.37 log units) below it; the measured number falls inside the stated range.
By their numbers in this assay, from the lowest: compounds 2 and 1 (each within the scatter of the next); then compound 3.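

In this assay, the bare carbon of the five-membered ring is where the series first loses ground: hydrogen in place of methyl gives a 4.4-fold higher number from compound 2 to compound 3 (0.64 log units; beyond the scatter) and hydrogen in place of nitrile gives a 4.3-fold higher number from compound 1 to compound 3 (0.64 log units; beyond the scatter) in this series. The level values of compound 1 and compound 2 therefore did not show that this carbon can go without a substituent. Nothing on hand bears on the reason for this loss.

Still open, going by these compounds, is whether a halogen, a methoxy group, an amine or a longer chain such as ethyl at this carbon matches methyl and nitrile. Also open, on these data alone, is whether the same loss appears with another group in place of the acrylic acid.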